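The compounds below may be only part of what the source reports. "The series", "measured", "known", "first", "only" and "open" are said of these compounds alone.

Compound 1 `Nc1nc2cc(-c3nn(CCCCCC(=O)NO)c4ncnc(N)c34)ccc2o1` carries a hydroxamic acid on a six-carbon chain from the shared core. Among the compounds with values here, in a functional assay on MCF7 cells (Homo sapiens) for inhibition, read by MTT assay, with a stated time of 72 h (a higher number here means a weaker inhibitor, a lower number a stronger inhibitor), compound 1 gives 12400 nM, the lowest of the two numbers so far, though compound 2 `Nc1ncnc2c1c(-c1cnc3[nH]ccc3c1)nn2CCCCCCCCC(=O)NO`, which gives 24700 nM in this assay, lies within the scatter of it, so the two cannot be told apart on these data.

Compound 3 `Nc1nc2cc(-c3nn(CCC(=O)NO)c4ncnc(N)c34)ccc2o1` keeps the core of compound 1 and differs in one place: hydroxycarbamoyl in place of 3-(hydroxycarbamoyl)propyl on a saturated chain carbon, two bonds along the chain from an aromatic nitrogen. Within the data shown here, no measured pair shows a step of this kind, so the size of the change can only be expected, not read off. The step from compound 1 to compound 3 is expected to weaken inhibition, a 2.8-fold higher number from compound 1 to compound 3 (0.45 log units; beyond the scatter), beyond the usual scatter. Compound 3 is therefore estimated at 35000 nM in this assay, with a range from 8000 nM to 150000 nM.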

Compound 3, half-maximal inhibitory concentration: > 100000 nM
Compound 3 was reported as a limit; the forecaster's own chance of this, stated with the estimate: 25%; middle value at least 2.8-fold (0.45 log units) away from the limit.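

At this position on the core of compound 1, the chain length bears on inhibition: with hydroxycarbamoyl in place of 3-(hydroxycarbamoyl)propyl on a saturated chain carbon, two bonds along the chain from an aromatic nitrogen, the data show an at least 8.0-fold higher number from compound 1 to compound 3 (0.90 log units; beyond the scatter). Within the data shown here, this is the first step read at this place, and it shows that the change weakens inhibition in this assay by an amount beyond the scatter. Compound 3 gives > 100000 nM, which is a limit of the assay and not a number, so the step is bounded from one side only: the limit of > 100000 nM in this assay, at which 1 of the 3 values shown sits.

As far as these compounds go, the full size of the step therefore stays unknown, as does the way inhibition changes with the chain lengths that lie along this series. From the compounds shown here alone, whether a longer chain on the core of compound 1, or a carboxylic acid in place of the hydroxycarbamoyl end, would strengthen or weaken inhibition in this assay remains open.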